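Dropping the phenyl from a pyridine-linked acid

A few compounds are considered here, and "the series" means these few. Any claim that something is new, unique, unknown or untested is made for them only; others in the source may bear on it.

Three compounds have been measured in an in vitro functional assay on 1321-N1 cells for agonist activity at Free fatty acid receptor 1 (Homo sapiens), read by fluorescence, spectrophotometry and calcium flux; on this read-out lower numbers stand for smaller maximal responses and higher numbers for larger maximal responses:

Compound 1, `O=C(O)CCc1ccc(C#Cc2ncccc2[N+](=O)[O-])cc1`, compound 1 gives 87%
Compound 2, `O=C(O)CCc1ccc(C#Cc2ccnc(-c3ccccc3)c2)cc1`, compound 2 gives 97%
Compound 3, `COc1nccc(C#Cc2ccc(CCC(=O)O)cc2)n1`, compound 3 gives 109%

All three share a propanoic acid on a phenyl ring joined through an alkyne to a six-membered aromatic ring carrying nitrogen. Compound 2 stands second highest of the three numbers. Its nearest neighbour is compound 1, whose value lies within the scatter of compound 2, so the two cannot be told apart; compound 3 lies beyond the scatter, above compound 2.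

Compound 4, `O=C(O)CCc1ccc(C#Cc2ccncc2)cc1`, has not yet been measured. It differs from compound 2 in one place: hydrogen in place of phenyl on an aromatic carbon. The three measured compounds reach similar large maximal responses despite quite different groups on the nitrogen-bearing ring, so no large shift is expected from this change. The step from a number 5 percentage points lower from compound 2 to compound 4 (within the scatter) is estimated to stay within the scatter, perhaps slightly downward. Compound 4 is expected to give about 92%, within 72% to 110%.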

Compound 4, largest response reached (reported as efficacy), in percent of the reference or control that the assay uses: 100%
Estimate against measurement, compound 4: 8 percentage points below; measured number inside the range.
By their numbers in this assay, from the lowest: compounds 1, 2, 4 and 3 (each within the scatter of the next, the first and the last beyond it).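

Putting hydrogen in place of phenyl on the aromatic carbon next to the ring nitrogen gives, in this assay, a number 3 percentage points higher from compound 2 to compound 4 (within the scatter). The two compounds cannot be told apart on this read-out, so the largest response at this position does not depend on having that extra ring of carbon only, and the smaller compound 4 keeps the full response of the larger compound 2. Nothing measured here bears on why the two compounds match.

The compounds shown leave open whether this position would accept a group of a quite different kind, such as an amine or a carboxylic acid, on the same carbon. As far as these compounds go, the largest response also says nothing about how much of each compound is needed to reach it, so that question stays open as well.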